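Adding a Chloro Group to an Amide With Limit-Only Toxicity

The source may hold more compounds than are shown below. What is called first, only, known or untested is meant among the compounds shown, and "the series" means these compounds.

In an ADME assay on HepG2 cells (Homo sapiens) for cytotoxicity, with a stated time of 72 h (a lower number here means that less compound is needed, a higher number that more compound is needed for the effect), compound 3 `O=C(Nc1cccc(-c2nc3ccccc3s2)c1)c1cc([N+](=O)[O-])ccc1Cl` gives > 27000 nM, which is a limit of the assay rather than a measured number. Compound 1 `O=C(Nc1cc(-c2nc3ccccc3s2)ccc1Cl)c1cc([N+](=O)[O-])ccc1Cl` gives > 25000 nM in this assay, again a limit. Compound 2 `O=C(Nc1cccc(-c2nc3ccccc3s2)c1)c1cc([N+](=O)[O-])c(O)cc1Cl` likewise gives > 25000 nM, also a limit. All three values shown are therefore limits, as the limit of > 25000 nM in this assay, at which 2 of the 3 values shown sit, and the limit of > 27000 nM in this assay, at which 1 of the 3 values shown sits, make clear, so compound 3 stands at the same edge as the other two and cannot be ranked against them. Compound 4 `O=C(Nc1ccc(Cl)c(-c2nc3ccccc3s2)c1)c1cc([N+](=O)[O-])ccc1Cl` differs from compound 3 by chloro in place of hydrogen on an aromatic carbon. Within the data shown here, two measured steps bear on this change: a step that the two limits leave unreadable from compound 1 to compound 3 and a step that the two limits leave unreadable from compound 2 to compound 3. Neither step has a readable size, and no direction for the new step can be drawn from them. Compound 4 is expected to stay in the same region, with an estimated step that the limit leaves unreadable from compound 3 to compound 4. Compound 4 is thus estimated at 30000 nM, in a range from 12000 nM to 100000 nM, and will most likely be reported once more only as a limit.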

Compound 4, half-maximal effective concentration: > 25000 nM
Compound 4 ended at the assay's limit (the forecaster's own chance of this, stated with the estimate: 85%); the middle value does not contradict the limit.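

Compound 3 and compound 4 both give only limits in this assay, so the step between them cannot be read. The compounds shown leave open what concentration any of them needs for the effect, and whether chloro in place of hydrogen changes it at all.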